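The compounds below may be only part of what the source reports. "The series", "measured", "known", "first", "only" and "open" are said of these compounds alone.

The study concerns four compounds that share one core and differ in two places. Compound 1 `O=S(=O)(/C=C/c1ccc(F)cc1Cl)Cc1ccc(Nc2ncnc3ccccc23)cc1` is tested in a functional assay on PC-3 cells (Homo sapiens) (a lower number here means a stronger inhibitor of growth, a higher number a weaker inhibitor of growth), and gives 100000 nM. Compound 2 `O=S(=O)(/C=C/c1ccc(C(F)(F)F)cc1F)Cc1ccc(Nc2ncnc3ccccc23)cc1` gives in this assay 100000 nM. The two differ only in one place, (2-chloro-4-fluorophenyl in place of 2-fluoro-4-(trifluoromethyl)phenyl on a double-bonded chain carbon bound to a double-bonded chain carbon), and that change makes a step of no change at the digits printed from compound 2 to compound 1 (within the scatter).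

Compound 3 `O=S(=O)(/C=C/c1ccc(C(F)(F)F)cc1F)Cc1ccc(Nc2ncnc3cc(Cl)ccc23)cc1` carries a different core, and the cores of compound 2 and compound 3 differ by chloro in place of hydrogen on an aromatic carbon. For compound 3 the result in this assay is only a limit, > 100000 nM. The step from compound 2 onward is therefore a number no lower from compound 2 to compound 3 (the limit leaves the size open), and the limit is the limit of > 100000 nM in this assay, at which 1 of the 3 values shown sits.

Compound 4 `O=S(=O)(/C=C/c1ccc(F)cc1Cl)Cc1ccc(Nc2ncnc3cc(Cl)ccc23)cc1` has not yet been measured. It stands to compound 3 as compound 1 stands to compound 2: the difference is 2-chloro-4-fluorophenyl in place of 2-fluoro-4-(trifluoromethyl)phenyl on a double-bonded chain carbon bound to a double-bonded chain carbon, and since the place is the same word for word, the change is the same as the one already seen. Because that change made a step of no change at the digits printed from compound 2 to compound 1 (within the scatter), the step from compound 3 to compound 4 in this assay is expected to be a number no higher from compound 3 to compound 4 (the limit leaves the size open). On this basis compound 4 is expected to give in this assay about 100000 nM, within a range from 50000 nM to 300000 nM, and the assay may again report only a limit.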

Compound 4, concentration for 50% growth inhibition: 73000 nM
Compound 4: the middle estimate sits 1.4-fold (0.14 log units) above what was measured; the range from low to high includes it.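

In this assay, the exchange of 2-fluoro-4-(trifluoromethyl)phenyl for 2-chloro-4-fluorophenyl gives an at least 1.3-fold lower number from compound 3 to compound 4 (0.13 log units; that floor lies within the scatter), and chloro in place of hydrogen on an aromatic carbon of the core gives a 1.4-fold lower number from compound 1 to compound 4 (0.14 log units; within the scatter). The first change therefore shows nothing on the second core that sets it apart from what was seen on the first, yet this does not establish that its effect carries over unchanged: the same change on two cores in this assay, no change at the digits printed (within the scatter) from compound 2 to compound 1 and an at least 1.3-fold lower number (0.13 log units; that floor lies within the scatter) from compound 3 to compound 4; the limit leaves it open whether they differ The chloro change can be read only as far as the same reservation allows, and its step from compound 2 to compound 3 has no readable size, as compound 3 is recorded only as a limit: the same change on two cores in this assay, a number no lower (the limit leaves the size open) from compound 2 to compound 3 and a 1.4-fold lower number (0.14 log units; within the scatter) from compound 1 to compound 4; the limit leaves it open whether they differ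

The compounds shown leave open how growth inhibition in this assay would respond to an amine or a carboxylic acid in place of the 2-chloro-4-fluorophenyl group. They also leave open whether either change would keep the same size on a compound whose value lies well clear of the limit, as all four values here stand close to it or at it.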